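The source may hold more compounds than are shown below. What is called first, only, known or untested is meant among the compounds shown, and "the series" means these compounds.

In a functional assay (aorta) with Rattus norvegicus as the target (on this read-out higher numbers stand for an effect only at larger amounts of compound and lower numbers for an effect already at smaller amounts), compound 1 `COc1ccc(-c2nc(/N=C(\N)N3CCOCC3)sc2-c2ccc(OC)cc2)cc1` gives 66 uM. Compound 2 `COc1ccc(-c2nc(C(=O)N=C(N)N)sc2-c2ccc(OC)cc2)cc1` reads > 100 uM, which is a limit of the assay and not a number. Among the compounds with values here, the only measured step, an at least 1.5-fold higher number from compound 1 to compound 2 (0.18 log units; that floor lies within the scatter), has a floor within the scatter and involves a different exchange. Compound 3 `COc1ccc(-c2nc(CCC(=O)O)sc2-c2ccc(OC)cc2)cc1` differs from compound 2 by a group of 5 heavy atoms (3 carbon, 2 oxygen; no ring) in place of a group of 6 heavy atoms (2 carbon, 3 nitrogen, 1 oxygen; no ring), on an aromatic carbon, placing 2-carboxyethyl on the same aromatic carbon. No step beyond the scatter is therefore expected in this assay. The estimated step is a number no higher from compound 2 to compound 3 (the limit leaves the size open). For compound 3 the expected value is 100 uM, within an estimated range of 40 uM to 250 uM.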

Compound 3, concentration for half-maximal effect: > 100 uM
Compound 3 gave a limit, no number (the forecaster's own chance of this, stated with the estimate: 50%); the middle value sits exactly at the limit.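

In this assay, this position now carries a second group, the nitrogen-free 2-carboxyethyl of compound 3, that ends at the same limit of the assay, not at a number: the limit of > 100 uM in this assay, at which 2 of the 3 values shown sit.

Against the morpholine-bearing compound 1, the record is an at least 1.5-fold higher number from compound 1 to compound 3 (0.18 log units; that floor lies within the scatter), so this floor does not separate the two. The step between compound 2 and compound 3 cannot be read, as both values are limits.

As far as these compounds go, how far either compound lies past the limit stays open. So does whether a primary amine or a longer chain ending in a carboxylic acid on this aromatic carbon would give a readable number.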